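A Bromo-for-Nitro Swap Carried From One Core to Another

The source may hold more compounds than are shown below. What is called first, only, known or untested is meant among the compounds shown, and "the series" means these compounds.

The study brings together two cores that are measured in a functional assay on MCF7 cells (Homo sapiens) for inhibition, read by sulforhodamine B assay, with a stated time of 48 h; a higher number here means a weaker inhibitor of growth, a lower number a stronger inhibitor of growth. The first is shared by compound 1 `N#CCC1=NN=C(c2ccc(Br)cc2)C(CC(=O)c2ccc(Br)cc2)O1` and compound 2 `N#CCC1=NN=C(c2ccc(Br)cc2)C(CC(=O)c2ccc([N+](=O)[O-])cc2)O1`. In this assay compound 1 gives 30400 nM, and compound 2 gives 32000 nM. The two differ in one place, (bromo in place of nitro on an aromatic carbon), and the step of a 1.1-fold lower number from compound 2 to compound 1 (0.02 log units; within the scatter) is small.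

Compound 3 `N#CCC1=C(C#N)CC(c2ccc([N+](=O)[O-])cc2)=C(CC(=O)c2ccc([N+](=O)[O-])cc2)O1` is built on a second core. In this assay compound 3 gives 30 nM, the lowest of the three numbers, and it stands far from both compound 1 and compound 2. How the core of compound 3 differs from that of compound 2 is not broken down here.

Compound 4 `N#CCC1=C(C#N)CC(c2ccc([N+](=O)[O-])cc2)=C(CC(=O)c2ccc(Br)cc2)O1` has not yet been measured. It differs from compound 3 in one place, (bromo in place of nitro on an aromatic carbon), and the place line reads the same as for the change from compound 2 to compound 1, so this is the same change seen again on the second core. Since that earlier step, a 1.1-fold lower number from compound 2 to compound 1 (0.02 log units; within the scatter), stayed within the scatter, the same is expected here: the step of a 1.1-fold lower number from compound 3 to compound 4 (0.03 log units; within the scatter) is estimated to be equally small. The expected number for compound 4 in this assay is 28 nM, with a range estimated from 10 nM to 90 nM, resting on compound 3 at 30 nM and on the earlier step.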

Compound 4, concentration for 50% growth inhibition: 4900 nM
For compound 4 the middle estimate is 180-fold (2.24 log units) below the measured one; measured number outside the range, above it.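

In this assay, the change from 4-nitrophenyl to 4-bromophenyl did not carry from one core to the other: the same change on two cores in this assay, a 1.1-fold lower number (0.02 log units; within the scatter) from compound 2 to compound 1 and a 160-fold higher number (2.21 log units; beyond the scatter) from compound 3 to compound 4, 170-fold (2.24 log units) apart, beyond the scatter of two such steps. On the core of compound 3 the swap is far from neutral, with a 160-fold higher number from compound 3 to compound 4 (2.21 log units; beyond the scatter), so the near-silent result on the core of compound 1 gave no safe guide to what the same swap would do on the second core. For the compounds shown here, this shows that, in these two pairs, the outcome of the change depends on the core that carries it, but with only one pair on each core it does not show why the two cores part ways, nor does it set a rule for the series as a whole.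

The compounds shown leave open how an amine, a carboxylic acid or a chloro group in the same place, on an aromatic carbon para to a large group, would read on each core, and so whether the nitro group of compound 3 is alone in giving the low number. They also leave open which feature of the core of compound 3 makes this place so sensitive, a question that further single changes within that core would be needed to settle.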